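This account rests on a few compounds, and the source may have more. Where it says the series, first, only, none or still open, it means among the compounds named here.

Of the compounds shown here, three sharing one core have been measured in an ADME assay on HEp-2 cells (Homo sapiens) for cytotoxicity; on this read-out higher numbers stand for lower toxicity in this test and lower numbers for higher toxicity in this test. Compound 1 `CC(C)CCn1c(Cn2c(=O)n(C(C)C)c3ccccc32)nc2cc(CN)ccc21`, which carries an aminomethyl group, gives 3920 nM. Its acetylated relative, compound 2 `CC(=O)NCc1ccc2c(c1)nc(Cn1c(=O)n(C(C)C)c3ccccc31)n2CCC(C)C`, gives 178000 nM. Compound 3 `CC(C)CCn1c(Cn2c(=O)n(C(C)C)c3ccccc32)nc2cc(C(N)=O)ccc21`, which carries a carbamoyl group, gives 23400 nM, the middle of the three numbers. Compound 4 `CC(C)CCn1c(Cn2c(=O)n(C(C)C)c3ccccc32)nc2cc(C(=O)N(C)C)ccc21` differs from compound 3 in one place: dimethylamino in place of amino on a carbonyl carbon. Put simply, dimethylamino stands in place of amino on a carbonyl carbon, so carbamoyl becomes dimethylcarbamoyl.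

Within the data shown here, no measured step makes this exact change. The nearest guide is a 45-fold higher number from compound 1 to compound 2 (1.66 log units; beyond the scatter), a large step in which acetyl replaces a hydrogen on an amine nitrogen. The modest steps of a 6.0-fold higher number from compound 1 to compound 3 (0.78 log units; beyond the scatter) and a 7.6-fold lower number from compound 2 to compound 3 (0.88 log units; beyond the scatter) exchange the whole group, so they show only that this position can move the number. A small rise is therefore expected, perhaps one that stays within the scatter. The expected change is a 1.5-fold higher number from compound 3 to compound 4 (0.17 log units; within the scatter). For compound 4 the estimated value is 35000 nM, with an expected range from 12000 nM to 110000 nM.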

Compound 4, half-maximal cytotoxic concentration: 25600 nM
The estimate for compound 4 lay 1.4-fold (0.14 log units) above the measured number, within the range that was stated.
By their numbers in this assay, from the lowest: compound 1; then compounds 3 and 4 (each within the scatter of the next); then compound 2.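

In this assay, dimethylamino in place of amino on this carbonyl carbon gives a 1.1-fold higher number from compound 3 to compound 4 (0.04 log units; within the scatter), so the amide nitrogen can carry dimethyl in place of its hydrogens, and lose the hydrogen-bond donor counted on amino, without a readable shift. Dimethylcarbamoyl stands clearly apart from the other two groups at this aromatic carbon, with a 6.5-fold higher number from compound 1 to compound 4 (0.81 log units; beyond the scatter) and a 7.0-fold lower number from compound 2 to compound 4 (0.84 log units; beyond the scatter), so compound 4 sits with compound 3 in the gap between compound 1 and compound 2. Nothing measured alongside these numbers explains them.

The compounds shown leave open whether a carboxylic acid or an amide nitrogen built into a pyrrolidine ring would also stay close to compound 3. They also leave open whether this flat step would hold with a shorter chain elsewhere on the shared core.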